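This account rests on a few compounds, and the source may have more. Where it says the series, first, only, none or still open, it means among the compounds named here.

In a functional assay on MCF7 cells (Homo sapiens) for inhibition, read by sulforhodamine B assay (on this read-out higher numbers stand for weaker inhibition of growth and lower numbers for stronger inhibition of growth), two compounds have been measured so far. Compound 1 (`COc1ccc(-c2ccc(-c3ccc(-c4nc5cc(C)ccc5[nH]4)cc3)cc2)cc1OC`) gives 190 nM, while compound 2 (`CN(C)c1ccc(-c2ccc(-c3ccc(-c4nc5c(O)cccc5[nH]4)cc3)cc2)cc1`) gives 2310 nM, the higher of the two numbers and so the weaker inhibition of growth. These two compounds differ in more than one place, so their gap cannot be assigned to any single group. Compound 3 (`COc1ccc(-c2ccc(-c3ccc(-c4nc5c(O)cccc5[nH]4)cc3)cc2)cc1OC`) is compound 2 with 3,4-dimethoxyphenyl in place of 4-(dimethylamino)phenyl on an aromatic carbon, para to a large group (3,4-dimethoxyphenyl in place of 4-(dimethylamino)phenyl on an aromatic carbon). Going by the values given here, the entering group also occurs in compound 1, which gives 190 nM, so some move towards stronger inhibition is expected, although no measured pair isolates this change. In this assay the expected change is a 3.3-fold lower number from compound 2 to compound 3 (0.52 log units; beyond the scatter), towards a lower number and beyond the scatter. The estimated value for compound 3 is 700 nM, with a range of 200 nM to 2400 nM.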

Compound 3, concentration for 50% growth inhibition: 190 nM
The estimate for compound 3 lay 3.7-fold (0.57 log units) above the measured number; the whole stated range lies above it.
By their numbers in this assay, from the lowest: compounds 1 and 3 (each within the scatter of the next); then compound 2.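

In this assay, 3,4-dimethoxyphenyl in place of 4-(dimethylamino)phenyl gives a 12-fold lower number from compound 2 to compound 3 (1.08 log units; beyond the scatter), showing that this one place alone can carry a large step, which the earlier pair, differing in more than one place, could not show. A second single change, 4-hydroxy-1H-benzimidazol-2-yl in place of 5-methyl-1H-benzimidazol-2-yl, gives no change at the digits printed from compound 1 to compound 3 (within the scatter), so these two groups cannot be told apart while 3,4-dimethoxyphenyl is present. No measurement at hand accounts for the size of the large step.

As far as these compounds go, it remains open how a single methoxy group, a carboxylic acid or a primary amine on this ring would read. From the compounds shown here alone, it is also open whether 5-methyl-1H-benzimidazol-2-yl and 4-hydroxy-1H-benzimidazol-2-yl would still match with 4-(dimethylamino)phenyl present.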